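A few compounds are considered here, and "the series" means these few. Any claim that something is new, unique, unknown or untested is made for them only; others in the source may bear on it.

Of the compounds shown here, three sharing a common core have been measured so far. Compound 1 `NS(=O)(=O)c1nnc(NCc2nc3ccccc3[nH]2)s1` gives 162000 nM in a functional assay on HepG2 cells (Homo sapiens) for cytotoxicity, read by MTT assay (a higher number here means a weaker inhibitor, a lower number a stronger inhibitor), the second highest of the three numbers. Compound 2 `Fc1ccc2nc(NCc3nc4ccccc4[nH]3)sc2c1` gives 233000 nM in this assay, and the two values lie within the scatter of each other, so nothing can be said of their order. Compound 3 `CC1=NN(Cc2nc3ccccc3[nH]2)C(=O)C1` gives 54000 nM in this assay, a lower number than compound 1, and this gap lies beyond the scatter.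

The next compound, compound 4 `NS(=O)(=O)c1nnc(NCc2nc3cc([N+](=O)[O-])ccc3[nH]2)s1`, differs from compound 1 in one place: nitro in place of hydrogen on an aromatic carbon. Within the data shown here, no pair of measured compounds separated by a single change is available, so the size and direction of this step cannot be read from the data. For compound 4 the step of a 1.4-fold lower number from compound 1 to compound 4 (0.13 log units; within the scatter) is expected to be small, without a firm direction and probably not beyond the scatter. Compound 4 is therefore estimated at 120000 nM in this assay, with a range from 40000 nM to 400000 nM.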

Compound 4, half-maximal inhibitory concentration: 184000 nM
The estimate for compound 4 lay 1.5-fold (0.19 log units) below the measured number, within the range that was stated.
By their numbers in this assay, from the lowest: compound 3; then compounds 1, 4 and 2 (each within the scatter of the next).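

In this assay, among these compounds, the step of a 1.1-fold higher number from compound 1 to compound 4 (0.06 log units; within the scatter) is the first single change that can be read. It shows that nitro in place of hydrogen, on this aromatic carbon of the six-membered aromatic ring of carbon only, gives no difference that can be told from scatter, so compound 1 and compound 4 cannot be put in order. This position on the core of compound 1 thus takes a group of 3 heavy atoms with no detectable shift in the read-out, and no measured evidence here bears on why.

As far as these compounds go, whether an amine, a methoxy group or a carboxylic acid on the same carbon would also stay within the scatter remains open. Also open, from the compounds shown here alone, is whether nitro would give a similar step when added to compound 2 or compound 3.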